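The source may report more compounds than this note shows. Statements on the series, on what has been measured and on what is new or still open speak of the compounds shown alone.

Measured so far:
compound 1 `CCOC(=O)c1cc(-c2cc(OC)c(OC)c(OC)c2)c(-c2ccc(OC)c(OCc3ccccc3)c2)s1`, > 100000 nM;
compound 2 `CCOC(=O)c1cc(-c2cc(OC)c(OC)c(OC)c2)c(-c2ccc(OC)c(O)c2)s1`, 1250 nM.

In a functional assay on KB cells (Homo sapiens) for antiproliferative activity, read by MTT assay, with a stated time of 72 h (on this read-out lower numbers stand for stronger inhibition and higher numbers for weaker inhibition), compound 1 reaches only the limit of the assay, > 100000 nM, rather than a number. Among the compounds with values here, compound 2 therefore gives the only number in this assay, 1250 nM. Within the data shown here, the step between them, an at least 80-fold lower number from compound 1 to compound 2 (1.90 log units; beyond the scatter), is the sole measured change, and it involves the oxygen on the aromatic ring, not the five-membered ring.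

Compound 3 `COc1ccc(-c2sccc2-c2cc(OC)c(OC)c(OC)c2)cc1O` is not yet measured. It differs from compound 2 in a single place: hydrogen in place of ethoxycarbonyl on an aromatic carbon. Among the measured compounds shown here, no measured step touches the ethoxycarbonyl group, so the benzyl-to-hydrogen step offers no guide, and the direction of the change on this assay cannot be anchored to anything measured. The expectation is a step within the scatter, a 1.4-fold lower number from compound 2 to compound 3 (0.14 log units; within the scatter). For compound 3 the estimate in this assay is 900 nM, within 150 nM to 5000 nM.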

Compound 3, half-maximal inhibitory concentration: 6270 nM
Beside the measured number, compound 3's estimate is 7.0-fold (0.84 log units) below it; the whole stated range lies below it.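

In this assay, the ethoxycarbonyl group on the aromatic carbon next to the ring sulfur now has a measured step of its own: a 5.0-fold higher number from compound 2 to compound 3 (0.70 log units; beyond the scatter). This position therefore responds to the change, although the step is modest beside the earlier change on the oxygen on the aromatic ring, an at least 80-fold lower number from compound 1 to compound 2 (1.90 log units; beyond the scatter). Compound 3 keeps the 3-hydroxy-4-methoxyphenyl group and, without the ester, still gives a number, 6270 nM, rather than a limit.

What the compounds shown leave open is why the number rises on this change, as nothing measured here speaks to its cause. They also leave open whether a carboxylic acid, an amide or a methyl group on this carbon would give a number nearer that of compound 2 or that of compound 3.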